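Carboxy removal on the aryloxy ring of the series

The compounds below may be only part of what the source reports. "The series", "measured", "known", "first", "only" and "open" are said of these compounds alone.

Compound 3 `COc1cc(OC[C@H](C)COc2ccc(C(=O)CC(C)(C)C)c(O)c2C)ccc1C(=O)O` gives 194 nM in an assay for positive allosteric modulation of metabotropic glutamate receptor 2 (Rattus norvegicus); a higher number here means that more compound is needed for the effect, a lower number that less compound is needed. Among the three measured compounds it holds the second highest number, yet both neighbours lie within the scatter of it: compound 2 `Cc1c(OC[C@@H](C)COc2ccc(C(=O)O)cc2F)ccc(C(=O)CC(C)(C)C)c1O` gives 222 nM, and compound 1 `Cc1c(OC[C@@H](C)COc2ccc(F)c(C(=O)O)c2)ccc(C(=O)CC(C)(C)C)c1O` gives 112 nM. Compound 4 `COc1cccc(OC[C@H](C)COc2ccc(C(=O)CC(C)(C)C)c(O)c2C)c1` differs from compound 3 by hydrogen in place of carboxy on an aromatic carbon. Among the compounds with values here, the single measured step, a 2.0-fold higher number from compound 1 to compound 2 (0.30 log units; within the scatter), exchanges one carboxy and fluoro pattern for another while a carboxy remains on the ring, so it speaks only to where the acid sits, not to its loss. Within the data shown here, no measured pair bears directly on the change leading to compound 4; the expectation therefore rests on no precedent and is set loosely, leaning toward a higher number since every measured compound carries the carboxy. The expected step is a 3.1-fold higher number from compound 3 to compound 4 (0.49 log units; beyond the scatter). The estimate for compound 4 is 600 nM, with a range from 150 nM to 3000 nM.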

Compound 4, half-maximal effective concentration: "not active" (no number reported)
The entry for compound 4 holds no number; no gap can be computed for the estimate.
By their numbers in this assay, from the lowest: compounds 1, 3 and 2 (each within the scatter of the next).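

In this assay, within the data shown here, compound 4 holds no number, so no step from compound 3 to it can be read. Nothing on hand bears on this result. The compounds shown leave open how far loss of the carboxy shifts the number from that of compound 3.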